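A few compounds are considered here, and "the series" means these few. Any claim that something is new, unique, unknown or untested is made for them only; others in the source may bear on it.

Compound 1, with the structure `CCN(Cc1ccc(Br)cc1)c1ccc(C(=O)N2CCc3ccc(OS(N)(=O)=O)cc3C2)cc1`, is the point of departure. Among the compounds with values here, in an assay on HEK293 cells for inhibition of Steryl-sulfatase (Homo sapiens), tested at 1 uM (a lower number here means a weaker effect, a higher number a stronger effect of the compound at the concentration tested), compound 1 gives 95.9%, the highest of the two numbers measured so far. Within the data shown here, its nearest neighbour is compound 2, with the structure `CCN(Cc1ccc(F)cc1)c1cccc(C(=O)N2CCc3ccc(OS(N)(=O)=O)cc3C2)c1`, which in this assay gives 66.5%; that number lies lower than the one for compound 1 by a gap beyond the usual scatter, so compound 1 is indeed the stronger of the two on this read-out.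

Compound 3, with the structure `CN(CCCN1CCCCC1)c1ccc(C(=O)N2CCc3ccc(OS(N)(=O)=O)cc3C2)cc1`, has not yet been measured. It differs from compound 1 in a single place: methyl(3-(piperidin-1-yl)propyl)amino in place of (4-bromobenzyl)(ethyl)amino on an aromatic carbon. Among the measured compounds shown here, no step between two measured compounds describes a change of this kind, so its size is not known from the data. Compound 1 already stands close to full inhibition at 95.9%, which leaves little room for an upward move. The step from compound 1 to compound 3 is therefore expected to be downward, and beyond the scatter, in the order of a number 27.9 percentage points lower from compound 1 to compound 3 (beyond the scatter). Compound 3 is expected to give about 68% in this assay, most likely between 40% and 92%.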

Compound 3, a percentage reported as inhibition, at one concentration (the size of the read-out at that concentration, not a potency): 40.7%
For compound 3 the middle estimate is 27.3 percentage points above the measured one, within the range that was stated.
By their numbers in this assay, from the lowest: compound 3; then compound 2; then compound 1.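

On the aromatic carbon para to a large group, the substituent matters a great deal: in this assay, placing methyl(3-(piperidin-1-yl)propyl)amino there in place of (4-bromobenzyl)(ethyl)amino gives a number 55.2 percentage points lower from compound 1 to compound 3 (beyond the scatter) while the rest of the molecule stays the same. Within the data shown here, this is the first change that can be read at this position, since compound 1 and compound 2 differ in more than one place. Both groups count 11 heavy atoms, so in this pair a matching heavy-atom count does not preserve the read-out, and nothing shown accounts for the drop.

The change replaces the bromine-bearing aromatic ring with a non-aromatic ring holding a nitrogen, and it also alters the chain and the small alkyl group on the attached nitrogen, so the compounds shown leave open which of these parts accounts for the step. A plain benzyl group in place of 4-bromobenzyl, a methyl group in place of the ethyl group beside 4-bromobenzyl, or a morpholine ring in place of the piperidine ring would each test one of these parts on its own.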